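The source may report more compounds than this note shows. Statements on the series, on what has been measured and on what is new or still open speak of the compounds shown alone.

Measured in a functional assay on SF-268 cells (Homo sapiens) for inhibition, read by sulforhodamine B assay, with a stated time of 48 h, tested at 10 uM; on this read-out higher numbers stand for more inhibition at the one concentration tested (going by the name of the read-out) and lower numbers for less inhibition:
compound 1 `c1ccc(-c2cn3ccnc3c(-c3ccc4ncn(C5CCCCC5)c4c3)n2)cc1` — 21.7%
compound 2 `Clc1ccc(-c2cn3ccnc3c(-c3ccc4ncn(C5CCCCC5)c4c3)n2)cc1` — 4.83%

For the measured compounds named here, compound 2 has the lowest of the two numbers; the nearest is compound 1, and the only measured step, a number 16.9 percentage points lower from compound 1 to compound 2 (beyond the scatter), is the one that separates them. Compound 3 `Fc1ccccc1-c1cn2ccnc2c(-c2ccc3ncn(C4CCCCC4)c3c2)n1` differs from compound 2 by 2-fluorophenyl in place of 4-chlorophenyl on an aromatic carbon. Going by the values given here, no measured step exchanges one substituted phenyl for another, so the step from compound 2 to compound 3 has no direct precedent; the step from compound 1 to compound 2 shows only that a chloro on that phenyl lowered inhibition. Compound 3 is expected to give about 12% (range -5% to 30%), an expected step of a number 7.2 percentage points higher from compound 2 to compound 3 (within the scatter) within the scatter.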

Compound 3, a percentage reported as inhibition, at one concentration (the size of the read-out at that concentration, not a potency): 6.04%
Compound 3: middle estimate off by 6 percentage points, on the high side; measured number inside the range.
By their numbers in this assay, from the lowest: compounds 2 and 3 (each within the scatter of the next); then compound 1.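

In this assay the exchange of 4-chlorophenyl for 2-fluorophenyl gives a number 1.2 percentage points higher from compound 2 to compound 3 (within the scatter) and so does not separate these two substituted phenyls on this read-out. Fluoro in place of hydrogen gives a number 15.7 percentage points lower from compound 1 to compound 3 (beyond the scatter) and so shows that the drop seen with chloro is not confined to the 4-chlorophenyl compound. No evidence on the cause is at hand.

Open, from the compounds shown here alone, is whether the drop belongs to halogens alone or also follows a methoxy or an amine on the same phenyl. Also open, going by these compounds, is how a carboxylic acid there would read.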